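Chain-Bound Amines on a Shared Chromone Core

This account rests on a few compounds, and the source may have more. Where it says the series, first, only, none or still open, it means among the compounds named here.

Of the compounds shown here, three of a shared core have been measured in an assay on isolated protein (Cavia porcellus) with Sigma non-opioid intracellular receptor 1 (Homo sapiens) as the target, read by radioligand binding; on this read-out lower numbers stand for stronger inhibition and higher numbers for weaker inhibition. Compound 1 `O=c1cc(-c2ccccc2)oc2cccc(OCCCN3CCC(O)CC3)c12` gives 91 nM. Compound 2 `CN(C)CCCCCCCCOc1ccc2oc(-c3ccccc3)cc(=O)c2c1` gives 143 nM, and compound 3 `CN(C)CCCCCCCCCOc1ccc2oc(-c3ccccc3)cc(=O)c2c1` gives 202 nM, the highest of the three numbers; the gap to compound 2 lies within the scatter, while the gap to compound 1 lies beyond it.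

Compound 4 `O=c1cc(-c2ccccc2)oc2ccc(OCCCCCCN3CCCCC3)cc12` is not yet measured. Its change from compound 3 is piperidin-1-yl in place of 3-(dimethylamino)propyl on a saturated chain carbon, six bonds along the chain from an oxygen on an aromatic ring. Within the data shown here, the only measured step that touches the chain is a 1.4-fold higher number from compound 2 to compound 3 (0.15 log units; within the scatter), so lengthening the chain by one carbon left the number essentially where it was. Among the measured compounds shown here, no measured pair shows an open-chain amine turned into a ring amine on the same chain; compound 1 carries a ring amine on a shorter chain at another position and gives the lowest number, but no step joins it to compound 3. For compound 4 the expected step is therefore a 1.6-fold lower number from compound 3 to compound 4 (0.19 log units; within the scatter), a move that stays within the scatter, with a slight lean toward a lower number. Compound 4 is thus estimated at 130 nM, between 45 nM and 400 nM.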

Compound 4, half-maximal inhibitory concentration: 54 nM
For compound 4 the middle estimate is 2.4-fold (0.38 log units) above the measured one, and the stated range covers the measured number.
By their numbers in this assay, from the lowest: compounds 4, 1, 2 and 3 (each within the scatter of the next, the first and the last beyond it).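

In this assay, piperidin-1-yl in place of 3-(dimethylamino)propyl, on a saturated chain carbon six bonds along the chain from an oxygen on an aromatic ring, gives a 3.7-fold lower number from compound 3 to compound 4 (0.57 log units; beyond the scatter) and so moves the number beyond the scatter. Against compound 2, the same kind of replacement, now of 2-(dimethylamino)ethyl, gives a 2.6-fold lower number from compound 2 to compound 4 (0.42 log units; beyond the scatter) and also lies beyond the scatter, whereas the only earlier step on the chain, a 1.4-fold higher number from compound 2 to compound 3 (0.15 log units; within the scatter), stayed within it. No measurement offered here accounts for this change.

Each of these steps alters the chain and the amine at once, so the compounds shown do not separate the piperidine ring from the shorter chain. As far as these compounds go, whether dimethylamino on the chain of compound 4, or a pyrrolidine or morpholine ring in place of the piperidine, would give a similar number remains open.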